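Replacing the indole of compound 2 with 3-methylphenyl

A few compounds are considered here, and "the series" means these few. Any claim that something is new, unique, unknown or untested is made for them only; others in the source may bear on it.

Compound 1 (`COc1cc(-c2ccnc3cc(-c4ccc(C)cc4)nn23)cc(OC)c1OC`) gives 47 nM
Compound 2 (`COc1cc(-c2ccnc3cc(-c4cn(C)c5ccccc45)nn23)cc(OC)c1OC`) gives 95 nM

In a functional assay on MCF7 cells (Homo sapiens) for inhibition, read by CCK-8 assay, with a stated time of 48 h (a lower number here means a stronger inhibitor, a higher number a weaker inhibitor), compound 2 stands at 95 nM as the higher of the two numbers, which makes it the weaker inhibitor of the pair. Going by the values given here, the only measured step (a 2.0-fold higher number from compound 1 to compound 2 (0.31 log units; beyond the scatter)) is modest but beyond the scatter. Compound 3 (`COc1cc(-c2ccnc3cc(-c4cccc(C)c4)nn23)cc(OC)c1OC`) has not yet been measured. It has 3-methylphenyl in place of 1-methyl-1H-indol-3-yl on an aromatic carbon. The measured step bears on this change from the other direction, since it brought in the same 1-methyl-1H-indol-3-yl group in place of 4-methylphenyl. Among the compounds with values here, no measured compound carries 3-methylphenyl, so the transfer is uncertain. A move toward a lower number is expected, of up to about the size of the measured step, and it may not clear the scatter. The estimated step (a 1.7-fold lower number from compound 2 to compound 3 (0.24 log units; within the scatter)) reflects that expectation. Compound 3 is estimated at 55 nM (expected range 22 nM to 130 nM).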

Compound 3, half-maximal inhibitory concentration: 1080 nM
Beside the measured number, compound 3's estimate is 20-fold (1.29 log units) below it; measured number above the stated range.
By their numbers in this assay, from the lowest: compound 1; then compound 2; then compound 3.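

At this position, on an aromatic carbon of a five-membered aromatic ring with 2 nitrogen, the change from 4-methylphenyl to 3-methylphenyl gives a 23-fold higher number from compound 1 to compound 3 (1.36 log units; beyond the scatter) in this assay, so two isomeric methylphenyl groups are far from interchangeable here. Replacing 1-methyl-1H-indol-3-yl with 3-methylphenyl gives an 11-fold higher number from compound 2 to compound 3 (1.06 log units; beyond the scatter), which makes compound 3 the weakest of the three and shows that the modest step between compound 1 and compound 2 did not reflect a general tolerance for aryl changes at this position. Nothing measured here explains why these groups differ so sharply.

The compounds shown leave open whether the loss belongs to 3-methylphenyl alone or extends to other groups, such as 2-methylphenyl, unsubstituted phenyl or 3-methoxyphenyl. They also leave open whether a 4-substituent other than methyl, such as an amine, a carboxylic acid or a longer alkyl chain, would keep the strength seen with compound 1 at 47 nM in this cell assay.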